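A few compounds are considered here, and "the series" means these few. Any claim that something is new, unique, unknown or untested is made for them only; others in the source may bear on it.

Three triazoles share one core and differ only in the aryl group on the ring nitrogen. Compound 1 `Oc1cc(C(F)(F)F)ccc1-c1nc(-c2ccccc2O)n(-c2ccc(F)cc2)n1` carries a 4-fluorophenyl there; in a functional assay on PC-12 cells (Rattus norvegicus) for cytotoxicity, read by MTT assay, with stated times of 2 h and 24 h, tested at 5 uM (on this read-out lower numbers stand for a weaker effect and higher numbers for a stronger effect at the one concentration tested), compound 1 gives 86.7%. Compound 2 `Oc1cc(C(F)(F)F)ccc1-c1nc(-c2ccccc2O)n(-c2ccc(Cl)cc2)n1` carries a 4-chlorophenyl, and in this assay compound 2 gives 87.3%, so the change chloro in place of fluoro on an aromatic carbon made a step of a number 0.6 percentage points higher from compound 1 to compound 2 (within the scatter). Compound 3 `Oc1cc(C(F)(F)F)ccc1-c1nc(-c2ccccc2O)n(-c2cccc(F)c2)n1` has the fluorine moved, the difference from compound 1 being (3-fluorophenyl in place of 4-fluorophenyl on an aromatic nitrogen); in this assay compound 3 gives 87.7%, a step of a number 1 percentage points higher from compound 1 to compound 3 (within the scatter) and, from the chloro compound, a number 0.4 percentage points higher from compound 2 to compound 3 (within the scatter).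

Compound 4 `Oc1cc(C(F)(F)F)ccc1-c1nc(-c2ccccc2O)n(-c2cccc(Cl)c2)n1` has not yet been measured. Relative to compound 3 the change is chloro in place of fluoro on an aromatic carbon. It is the same kind of change as from compound 1 to compound 2, but not the same: there the place was para to a large group, here it is meta to a large group. Because the earlier exchange gave a number 0.6 percentage points higher from compound 1 to compound 2 (within the scatter), the step of a number 0.2 percentage points lower from compound 3 to compound 4 (within the scatter) is expected to be within the scatter as well. Compound 4 is therefore estimated at 87.5% in this assay, with a likely range from 81% to 93%.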

Compound 4, a percentage reported as activity, at one concentration (the size of the read-out at that concentration, not a potency): 92.7%
For compound 4 the middle estimate is 5.2 percentage points below the measured one; low and high end bracket the measured number.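

In this assay chloro in place of fluoro on an aromatic carbon, here meta to a large group, gave a number 5 percentage points higher from compound 3 to compound 4 (within the scatter) and the two readings of this change do not differ: the same change on two cores in this assay, a number 0.6 percentage points higher (within the scatter) from compound 1 to compound 2 and a number 5 percentage points higher (within the scatter) from compound 3 to compound 4, 4.4 percentage points apart, within the scatter of two such steps. The steps from the two 4-substituted compounds read the same way, with a number 5.4 percentage points higher from compound 2 to compound 4 (within the scatter) and a number 6 percentage points higher from compound 1 to compound 4 (within the scatter) and so none of these steps stands clear of the scatter. This shows that the exchange carried from one core to the other here without a detectable difference in its size, but it does not show that the exchange would behave alike on any further core, and a reading at a single concentration says nothing about potency.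

The aryl groups shown carry only fluoro or chloro, so it remains open how the read-out would respond to an amine, a carboxylic acid or a longer chain on that ring. The trifluoromethyl group and the two hydroxyl groups stay the same throughout, so nothing can be said about changing them.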